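The source may hold more compounds than are shown below. What is called first, only, known or untested is meant among the compounds shown, and "the series" means these compounds.

Measured so far:
compound 1 `COc1cc(O)c(C(=O)/C=C/c2ccc(O)c(O)c2)c(OC)c1` with 31600 nM
compound 2 `CCc1ccccc1/C=C/C(=O)c1c(O)cc(OC)cc1OC` with 2500 nM

The read-out throughout is a functional assay on B16-F10 cells (Mus musculus) for inhibition, with a stated time of 4 days (on this read-out lower numbers stand for stronger inhibition and higher numbers for weaker inhibition), and both values come from it. Compound 2 holds the lower of the two numbers, and its gap to compound 1 lies beyond the scatter. Among the compounds with values here, these two compounds differ in more than one place, so the measured pair offers no single-place step as a guide.

Next comes compound 3 `COc1cc(O)c(C(=O)/C=C/c2ccccc2OC)c(OC)c1` which carries methoxy in place of ethyl on an aromatic carbon, ortho to a large group (methoxy in place of ethyl on an aromatic carbon) and has yet to be measured. The only further hint is weak: compound 1 also lacks the ethyl and stands at 31600 nM on the higher side. In this assay no step beyond the scatter is therefore expected, with a slight lean towards a higher number. The expected move is a 1.6-fold higher number from compound 2 to compound 3 (0.20 log units; within the scatter) and it remains an estimate resting on a single comparison. For compound 3 the estimated value is 4000 nM with an expected range from 1400 nM to 12000 nM for a measurement in this series.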

Compound 3, half-maximal inhibitory concentration: 3800 nM
Compound 3: the middle estimate sits 1.1-fold (0.02 log units) above what was measured; low and high end bracket the measured number.
By their numbers in this assay, from the lowest: compounds 2 and 3 (each within the scatter of the next); then compound 1.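

In this assay, within the data shown here, the first single-place step comes from methoxy in place of ethyl on an aromatic carbon, ortho to a large group, and it reads a 1.5-fold higher number from compound 2 to compound 3 (0.18 log units; within the scatter) and so gives no separation between the two groups at this position. The exchange keeps the size at 2 heavy atoms while replacing 2 carbon with 1 carbon and 1 oxygen and adding 1 hydrogen-bond acceptor, and on this read-out that exchange leaves the two compounds indistinguishable. No measured information on either group bears on this result, so the step stands as an observation without an explanation.

Going by these compounds, the two groups compared here are similar in size, so it remains open whether an amine, a carboxylic acid or a longer chain such as butoxy on the same aromatic carbon would also stay within the scatter of compound 2 or would move the number beyond it. On these data alone, it also remains open whether methoxy in place of ethyl would give a similar step at another place on that ring or on a different core.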